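The compounds below may be only part of what the source reports. "The series", "measured", "known", "first", "only" and "open" are said of these compounds alone.

For the measured compounds named here, in a functional assay on HepG2 cells (Homo sapiens) for inhibition, read by MTT assay, with a stated time of 48 h (a lower number here means a stronger inhibitor, a higher number a weaker inhibitor), compound 1 (`CCc1ccc(-c2nc3ccccn3c2Sc2ccccc2)cc1`) gives 50200 nM and compound 2 (`c1ccc(Sc2c(-c3ccccc3)nc3ccc(-c4ccccc4)cn23)cc1`) gives 47800 nM and these two numbers lie within the usual scatter of each other, so compound 1 stands level with the only other compound measured. Compound 3 (`c1ccc(Sc2c(-c3ccsc3)nc3ccccn23)cc1`) carries thiophen-3-yl in place of 4-ethylphenyl on an aromatic carbon and keeps the rest of compound 1 unchanged. Going by the values given here, no measured pair shows what such a swap does, so the expected step is none beyond the scatter (a 1.1-fold higher number from compound 1 to compound 3 (0.04 log units; within the scatter) as estimated). Compound 3 is expected at 55000 nM with 20000 nM to 120000 nM as its estimated range.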

Compound 3, half-maximal inhibitory concentration: 49600 nM
Compound 3: the middle estimate sits 1.1-fold (0.04 log units) above what was measured; the measured number falls inside the stated range.
By their numbers in this assay, from the lowest: compounds 2, 3 and 1 (each within the scatter of the next).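

In this assay, for the compounds shown here, putting thiophen-3-yl in place of 4-ethylphenyl on this aromatic carbon gives a 1.0-fold lower number from compound 1 to compound 3 (0.01 log units; within the scatter) and is the first single-place change that can be read here. The smaller five-membered ring, with 5 heavy atoms against 8 and a hydrogen-bond acceptor that 4-ethylphenyl lacks, leaves compound 3 level with compound 1. No supporting measurement explains why the two stand level. As far as these compounds go, whether an amine or a carboxylic acid on this carbon would give a different number stays open. So does the effect of a longer chain in place of the ethyl group.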